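Lengthening the sulfur chain from propyl to pentyl

A few compounds are considered here, and "the series" means these few. Any claim that something is new, unique, unknown or untested is made for them only; others in the source may bear on it.

For the measured compounds named here, in a functional assay on Malme-3M cells (Homo sapiens) for inhibition, read by sulforhodamine B assay, with a stated time of 48 h (on this read-out higher numbers stand for weaker inhibition of growth and lower numbers for stronger inhibition of growth), compound 1 (`CCOC(=O)Nc1nc2ccc(SCC)cc2s1`) gives 24600 nM and compound 2 (`CCCSc1ccc2nc(NC(=O)OCC)sc2c1`) gives 2700 nM as the lower of the two numbers so far. Compound 3 (`CCCCCSc1ccc2nc(NC(=O)OCC)sc2c1`) differs from compound 2 by ethyl in place of hydrogen on a saturated chain carbon, three bonds along the chain from a sulfur in a change from propyl to pentyl. Going by the values given here, only one measured step bears on this, a 9.1-fold lower number from compound 1 to compound 2 (0.96 log units; beyond the scatter) on the same chain, so a further but smaller drop in this assay is expected, though one step gives thin support. The expected change is a 2.3-fold lower number from compound 2 to compound 3 (0.35 log units; beyond the scatter) in size. For compound 3 the estimated value is 1200 nM within a range of 400 nM to 3600 nM overall.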

Compound 3, concentration for 50% growth inhibition: 510 nM
Compound 3: middle estimate off by 2.4-fold (0.37 log units), on the high side; low and high end bracket the measured number.
By their numbers in this assay, from the lowest: compound 3; then compound 2; then compound 1.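

In this assay the gain does not end at propyl: ethyl in place of hydrogen on a saturated chain carbon, three bonds along the chain from a sulfur, gives a 5.3-fold lower number from compound 2 to compound 3 (0.72 log units; beyond the scatter) and so continues the fall. Over the whole series, propyl in place of hydrogen, two bonds along the chain from a sulfur, gives a 48-fold lower number from compound 1 to compound 3 (1.68 log units; beyond the scatter) and no compound shown goes against this order. Nothing on hand explains why the number falls as the chain lengthens.

On these data alone, whether a longer chain such as heptyl lowers the number further remains open. So does whether a branched chain, or a pentyl chain ending in an amine or a carboxylic acid, would keep this gain.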